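The compounds below may be only part of what the source reports. "The series", "measured", "known", "first", "only" and "open" are said of these compounds alone.

The measured compounds:
compound 1, `CC[C@@]1(c2ccccc2)COc2c(C(=O)NC)cc(C(=O)N[C@H]3[C@@H]4COC[C@@H]43)cc21`, with >= 152 ug/mL in a physicochemical assay for solubility; a higher number here means a more soluble compound, a lower number a less soluble compound
compound 2, `CNC(=O)c1cc(C(=O)NC2CC2)cc2c1OC[C@H]2c1cccc(OC)c1`, with >= 161 ug/mL
compound 3, `CNC(=O)c1cc(C(=O)NC2CC2)cc2c1OC[C@H]2c1cccc2[nH]ccc12`, with >= 142 ug/mL

In this assay compound 1 stands at >= 152 ug/mL, which is a limit of the assay and not a number, as the limit of >= 152 ug/mL in this assay, at which 1 of the 3 values shown sits, records. Compound 2 likewise sits at a limit, (the limit of >= 161 ug/mL in this assay, at which 1 of the 3 values shown sits). Compound 3 sits at a limit as well, (the limit of >= 142 ug/mL in this assay, at which 1 of the 3 values shown sits). Going by the values given here, the single step among the measured compounds, a step that the two limits leave unreadable from compound 2 to compound 3, cannot be read because both of its ends are limits, so it gives no size and no direction.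

Compound 4, `CNC(=O)c1cc(C(=O)N[C@H]2[C@@H]3COC[C@@H]32)cc2c1OC[C@@]2(C)c1ccccc1`, differs from compound 1 by hydrogen in place of methyl on a saturated chain carbon bound to a saturated ring carbon. Among the compounds with values here, no measured step follows this change, and the one step that exists is unreadable, so nothing among the measured compounds points to a shift in either direction. The account therefore expects compound 4 to reach the same limit as compound 1, and the step of an at least 1.0-fold lower number from compound 1 to compound 4 (0.00 log units; that floor lies within the scatter) is expected to be none beyond the scatter. For compound 4 the estimated value in this assay is 150 ug/mL, with a range from 75 ug/mL to 300 ug/mL, most likely again reported only as a limit.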

Compound 4, solubility: >= 147 ug/mL
Compound 4 was reported as a limit (the forecaster's own chance of this, stated with the estimate: 80%); the middle value does not contradict the limit.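

In this assay, going by these compounds alone, compound 4 gives >= 147 ug/mL, which is a limit of the assay and not a number; compound 1 also stands at a limit, so no step from compound 1 to compound 4 can be read. The compounds shown leave open whether hydrogen in place of methyl at this place shifts the read-out at all.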